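Swapping an Imidazole for Dimethylamine on an Alkyne Chain

The source may hold more compounds than are shown below. What is called first, only, known or untested is meant among the compounds shown, and "the series" means these compounds.

Compound 1 `CC1CCC(=O)N1CC#CCn1ccnc1` and compound 2 `CC1CCC(=O)N1CC#CCN(C)C` share one core and differ by dimethylamino in place of 1H-imidazol-1-yl on a saturated chain carbon bound to a triple-bonded carbon. In a functional assay on the whole organism for agonist activity, with Mus musculus as the target (a higher number here means that more compound is needed for the effect, a lower number that less compound is needed), compound 1 gives only a limit, > 100 mg/kg. In this assay compound 2 gives 3.7 mg/kg. The step is an at least 27-fold lower number from compound 1 to compound 2 (1.43 log units; beyond the scatter), and it is a floor on the true size since compound 1 sits at the limit of > 100 mg/kg in this assay, at which 1 of the 3 values shown sits. Compound 3 `O=C1NCCN1CC#CCn1ccnc1` carries a different core; how the two cores differ is not broken down here. In this assay compound 3 gives 30 mg/kg, the highest number among the measured compounds. Compound 4 `CN(C)CC#CCN1CCNC1=O` differs from compound 3 by dimethylamino in place of 1H-imidazol-1-yl on a saturated chain carbon bound to a triple-bonded carbon, the same change that separates compound 1 from compound 2, at the same place on the chain. A step of similar size is expected here, a 20-fold lower number from compound 3 to compound 4 (1.30 log units; beyond the scatter), resting on an at least 27-fold lower number from compound 1 to compound 2 (1.43 log units; beyond the scatter) seen on the other core. Compound 4 is therefore estimated at 1.5 mg/kg, most likely between 0.4 mg/kg and 6 mg/kg.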

Compound 4, dose for half-maximal effect: 9.7 mg/kg
Estimate against measurement, compound 4: 6.5-fold (0.81 log units) below, outside the stated range (above it).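

In this assay the swap to dimethylamino lowers the number on both cores, and the new pair shows a 3.1-fold lower number from compound 3 to compound 4 (0.49 log units; beyond the scatter), so the direction of the change carries over from one core to the other, but its size does not: the same change on two cores in this assay, an at least 27-fold lower number (1.43 log units; beyond the scatter) from compound 1 to compound 2 and a 3.1-fold lower number (0.49 log units; beyond the scatter) from compound 3 to compound 4, at least 8.7-fold (0.94 log units) apart, beyond the scatter of two such steps. Compound 1 gives > 100 mg/kg, which is a limit of the assay and not a number, so the earlier step is known only as a floor. These two pairs show that the swap pays off on both cores, but they do not show why its size differs, and they give no reliable size for the same swap on a further core.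

The compounds shown leave open whether another amine, such as pyrrolidine or piperidine, would do as well as dimethylamino on either core, and whether a longer chain would alter the step. Also open, from the compounds shown here alone, is how the same swap would read on a third core.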